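A few compounds are considered here, and "the series" means these few. Any claim that something is new, unique, unknown or untested is made for them only; others in the source may bear on it.

Working notes on the series. In a physicochemical assay for lipophilicity, read by HPLC, at pH 2.7 (on this read-out lower numbers stand for lower lipophilicity and higher numbers for higher lipophilicity), compound 1 `N#Cc1c(N2CCCCC2)c2sc3ccccc3c2n2c1nc1ccccc12` gives 7.7 and compound 3 `N#Cc1cc2sc3cc(N4CCCCC4)ccc3c2n2c1nc1ccccc12` gives 8.52; the two share their atoms joined differently, and the difference between the two cores is not broken down here. Compound 2 `CN(C)CCCNc1c(C#N)c2nc3ccccc3n2c2c1sc1ccccc12` gives 0.69 in this assay, which is a number 7.01 log units lower from compound 1 to compound 2 (beyond the scatter); the change is (3-(dimethylamino)propyl)amino in place of piperidin-1-yl on an aromatic carbon. Compound 4 `CN(C)CCCNc1ccc2c(c1)sc1cc(C#N)c3nc4ccccc4n3c12` carries the same kind of change on the core of compound 3, ((3-(dimethylamino)propyl)amino in place of piperidin-1-yl on an aromatic carbon), here on a ring of carbon only, meta and para to a fused ring, rather than on a ring with one nitrogen ortho to a cyano group. The step is expected to be a number 7.02 log units lower from compound 3 to compound 4 (beyond the scatter) in this assay, resting on the step of compound 1 to compound 2 a number 7.01 log units lower from compound 1 to compound 2 (beyond the scatter). Compound 4 is therefore estimated at 1.5, expected between 0.7 and 2.6.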

Compound 4, distribution coefficient: 1.03
Compound 4: the middle estimate sits 0.47 log units above what was measured, within the range that was stated.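

In this assay the change of piperidin-1-yl to (3-(dimethylamino)propyl)amino gives a number 7.49 log units lower from compound 3 to compound 4 (beyond the scatter) and a number 7.01 log units lower from compound 1 to compound 2 (beyond the scatter) in the two pairs, so the large drop carries from one core to the other. This holds for the aromatic carbon of each of these two cores, and with one pair per core it supports no rule for other cores. Nothing at hand accounts for the size of either step.

The compounds shown leave open whether morpholin-4-yl or a longer chain ending in diethylamino would give a step of this kind on either core. They also leave open how much of the step follows loss of the ring and how much follows the chain's terminal dimethylamino group.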